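This account rests on a few compounds, and the source may have more. Where it says the series, first, only, none or still open, it means among the compounds named here.

Compound 1 `CSc1nncc2c(C)nc(C)n12`: in a functional assay for inhibition, with Homo sapiens as the target (on this read-out higher numbers stand for weaker inhibition and lower numbers for stronger inhibition), compound 1 gives > 48000 nM, which is a limit of the assay.
Compound 2 `CCc1nc(C)c2cnnc(SC)n12`: compound 2 gives > 48000 nM, also a limit.
Compound 3 `CSc1nncc2c(C)nc(C(C)C)n12`: compound 3 gives > 48000 nM, again a limit.

Compound 1 therefore stands at a limit and not at a number, and so do the two others (the limit of > 48000 nM in this assay, at which 3 of the 3 values shown sit). The steps a step that the two limits leave unreadable from compound 1 to compound 2 and a step that the two limits leave unreadable from compound 1 to compound 3 are unreadable, and so is a step that the two limits leave unreadable from compound 2 to compound 3. Compound 4 `C=CCSc1nncc2c(C)nc(C)n12` differs from compound 1 by vinyl in place of hydrogen on a saturated chain carbon bound to a sulfur. The measured steps bear on this change only in that none of them yielded a readable size, so no direction can be taken from them. Compound 4 is expected to sit near the same limit, with a number no higher from compound 1 to compound 4 (the limit leaves the size open) not readable beyond the scatter. The estimate for compound 4 is 48000 nM, in the range 20000 nM to 100000 nM.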

Compound 4, half-maximal inhibitory concentration: 59000 nM
For compound 4 the middle estimate is 1.2-fold (0.09 log units) below the measured one; measured number inside the range.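

No new step can be read between compound 1 and compound 4, since the value of compound 1 is a limit and not a number: the limit of > 48000 nM in this assay, at which 3 of the 4 values shown sit. The compounds shown leave open which change to the shared core would give a readable step in this assay.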